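Amino addition to the phenyl methoxy nucleoside

The source may report more compounds than this note shows. Statements on the series, on what has been measured and on what is new or still open speak of the compounds shown alone.

Measured in a functional assay on HCT-116 cells (Homo sapiens), read by MTT assay, with a stated time of 72 h; a higher number here means a weaker inhibitor, a lower number a stronger inhibitor:
- compound 1 `COc1ncnc2c1c(-c1ccccc1)cn2[C@@H]1O[C@H](CO)[C@@H](O)[C@H]1O`: > 20000 nM
- compound 2 `C#Cc1cn([C@@H]2O[C@H](CO)[C@@H](O)[C@H]2O)c2ncnc(OC)c12`: 5140 nM
- compound 3 `CSc1ncnc2c1c(-c1ccccc1)cn2[C@@H]1O[C@H](CO)[C@@H](O)[C@H]1O`: > 20000 nM

Compound 1 sits at the limit of > 20000 nM in this assay, at which 2 of the 3 values shown sit. This value is a limit and not a number, so the start of the step has no exact position. Compound 3 gives > 20000 nM, which is also a limit.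

Compound 4 `COc1nc(N)nc2c1c(-c1ccccc1)cn2[C@@H]1O[C@H](CO)[C@@H](O)[C@H]1O` differs from compound 1 as follows: amino in place of hydrogen on an aromatic carbon. The new group stands on the carbon between two ring nitrogen atoms.

Neither measured step changes that carbon, so both bear on it only indirectly. Among the measured compounds shown here, the one readable step, an at least 3.8-fold lower number from compound 1 to compound 2 (0.59 log units; beyond the scatter), exchanges phenyl for ethynyl, and phenyl stays in compound 4. The methylsulfanyl step cannot be sized, as both of its ends are limits. No sizeable drop in this assay is therefore expected, although a modest lowering cannot be excluded.

The estimated change is a number no higher from compound 1 to compound 4 (the limit leaves the size open). Compound 4 is expected at 20000 nM, with an estimated range of 8000 nM to 40000 nM.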

Compound 4, half-maximal inhibitory concentration: > 20000 nM
Compound 4: only a limit was reported; the forecaster's own chance of this, stated with the estimate: 70%; the middle value sits exactly at the limit.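

In this assay compound 4 gives > 20000 nM, which is a limit. Compound 1 gives > 20000 nM, also a limit, so no step can be read between compound 1 and compound 4. The compounds shown leave open whether amino in place of hydrogen changes the number at all.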